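Replacing the aryl group of compound 3

The compounds below may be only part of what the source reports. "The series", "measured", "known", "first", "only" and "open" are said of these compounds alone.

In a functional assay on MDA-MB-231 cells (Homo sapiens) for cytotoxicity, read by MTT assay, with a stated time of 48 h (on this read-out higher numbers stand for weaker inhibition and lower numbers for stronger inhibition), compound 1 `O=C(NCCCCN(c1ccc(F)cc1)c1ccc(F)cc1)Nc1ccc(Cl)cc1` gives > 20000 nM, which is a limit of the assay and not a number. Compound 2 `O=C(NCCCCN(c1ccc(F)cc1)c1ccc(F)cc1)Nc1ccc(I)cc1` gives > 20000 nM, again only a limit. Within the data shown here, compound 3 `O=C(NCCCCN(c1ccc(F)cc1)c1ccc(F)cc1)Nc1ccc(Cl)c(C(F)(F)F)c1` gives 5040 nM, the only true number so far, and it is the strongest of the three.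

The next compound is compound 4 `O=C(NCCCCN(c1ccc(F)cc1)c1ccc(F)cc1)Nc1ccc(Br)cc1I`, and the change is 4-bromo-2-iodophenyl in place of 4-chloro-3-(trifluoromethyl)phenyl on an amide-type nitrogen. In words, 4-bromo-2-iodophenyl comes in place of 4-chloro-3-(trifluoromethyl)phenyl on an amide-type nitrogen, so the trifluoromethyl group is lost.

Among the measured compounds shown here, three measured steps bear on this. Trifluoromethyl in place of hydrogen on an aromatic carbon gave an at least 3.9-fold lower number from compound 1 to compound 3 (0.59 log units; beyond the scatter). Changing the whole aryl group gave an at least 3.9-fold lower number from compound 2 to compound 3 (0.59 log units; beyond the scatter). Iodo in place of chloro gave a step that the two limits leave unreadable from compound 1 to compound 2, so that step offers no guide to the effect of swapping one halogen for another.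

Like compound 1 and compound 2, compound 4 carries halogens but no trifluoromethyl, so a move back toward weaker inhibition is expected. The expected change is a 2.8-fold higher number from compound 3 to compound 4 (0.44 log units; beyond the scatter). A reading that is again only a limit would be no surprise. For compound 4 the estimate is 14000 nM, with an expected range from 5000 nM to 30000 nM.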

Compound 4, half-maximal inhibitory concentration: > 20000 nM
Compound 4 was reported as a limit (the forecaster's own chance of this, stated with the estimate: 50%); middle value at least 1.4-fold (0.15 log units) from the limit.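

In this assay, moving to the 4-bromo-2-iodophenyl group gives an at least 3.9-fold higher number from compound 3 to compound 4 (0.59 log units; beyond the scatter). Compounds 1 and 2 carry a single halogen on this aryl group, whereas compound 4 carries two, so it adds something they could not show: a second halogen at this place on the amide-type nitrogen does not by itself bring back the activity seen with compound 3. Among these four compounds, only compound 3, the one with a trifluoromethyl group, gives a true number, and compound 4 cannot be ranked against compound 1 or compound 2 because all three stop at the same ceiling, so their steps cannot be read: the limit of > 20000 nM in this assay, at which 3 of the 4 values shown sit.

The compounds shown leave open whether trifluoromethyl works on its own or needs the chloro group on the same ring, and whether a nitrile or a methoxy group in its place would also give a true number. They also leave open how far compound 3 itself could be improved, for instance by a longer chain in the shared core, since every change here is on the aryl group.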